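The source may hold more compounds than are shown below. What is called first, only, known or untested is meant among the compounds shown, and "the series" means these compounds.

Working notes on cytotoxicity in the series. Compound 1 `Fc1ccc2[nH]c(-c3cn(-c4ccccc4)nc3-c3ccccc3)nc2c1`, compound 2 `COc1ccc2[nH]c(-c3cn(-c4ccccc4)nc3-c3ccccc3)nc2c1` and compound 3 `O=C(OCc1ccccc1)c1ccc2[nH]c(-c3cn(-c4ccccc4)nc3-c3ccccc3)nc2c1` share one core and differ only in the group on one aromatic carbon. In an ADME assay on HaCaT cells (Homo sapiens) for cytotoxicity, read by MTT assay, with a stated time of 48 h (on this read-out higher numbers stand for weaker inhibition and lower numbers for stronger inhibition), compound 1 gives > 50000 nM, which is a limit of the assay rather than a number. In this assay compound 2 gives > 50000 nM, again a limit. In this assay compound 3 gives > 50000 nM, also a limit. Compound 3 thus stands at the same limit as the other two members, and the steps a step that the two limits leave unreadable from compound 1 to compound 2, a step that the two limits leave unreadable from compound 1 to compound 3 and a step that the two limits leave unreadable from compound 2 to compound 3 cannot be sized because all three values sit at the limit of > 50000 nM in this assay, at which 3 of the 3 values shown sit.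

Compound 4 `O=C(OCc1ccccc1)c1ccc2[nH]c(-c3cn(-c4ccccc4)nc3-c3ccc(Cl)cc3)nc2c1` is not yet measured. Its difference from compound 3 is chloro in place of hydrogen on an aromatic carbon, a change at a position that none of the three measured steps touches; those steps concern the other aromatic carbon and are in any case unreadable. For the measured compounds named here, no measured step therefore bears on the present change, and the only guide is that the whole series so far rests at the limit.

Compound 4 is accordingly expected to stay at the limit in this assay, with an estimate of 80000 nM in a range of 30000 nM to 300000 nM. The expected step that the limit leaves unreadable from compound 3 to compound 4 is none beyond the scatter.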

Compound 4, half-maximal inhibitory concentration: > 50000 nM
Compound 4: only a limit was reported; the forecaster's own chance of this, stated with the estimate: 85%; the middle value does not contradict the limit.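

In this assay compound 4 gives > 50000 nM, a limit and not a number. Compound 3 also rests at a limit, so the step from phenyl to 4-chlorophenyl between these two compounds cannot be read: the limit of > 50000 nM in this assay, at which 4 of the 4 values shown sit.

The compounds shown leave open whether any group at either changed position alters cytotoxicity, since none has a readable value.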